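The compounds below may be only part of what the source reports. "The series", "measured", "known", "first", "only" and "open" are said of these compounds alone.

Compound 1, `COC(=O)C[C@H](NC(=O)OC(C)(C)C)C(=O)N(Cc1ccc(F)cc1)C1(C(=O)NCc2ccccc2)CCN(C2CCCCC2)CC1`, compound 2, `COC(=O)C[C@H](NC(=O)OC(C)(C)C)C(=O)N(Cc1ccc(F)cc1)C1(C(=O)NC(C)(C)C)CCN(Cc2ccccc2)CC1`, and compound 3, `COC(=O)C[C@H](NC(=O)OC(C)(C)C)C(=O)NC1(C(=O)NCc2ccccc2)CCN(Cc2ccccc2)CC1`, share one core and have all been run in an ADME assay on MDCK cells (Canis lupus familiaris) for cytotoxicity, read by microscopy, with a stated time of 72 h; a lower number here means that less compound is tolerated, a higher number that more compound is tolerated. Compound 1 gives 73000 nM, compound 2 gives 80000 nM and compound 3 gives 100000 nM. Compound 3 therefore holds the highest of the three numbers, yet compound 2 and compound 1 both lie within the scatter of it, so no order among the three can be read. Compound 4, `COC(=O)C[C@H](NC(=O)OC(C)(C)C)C(=O)N(Cc1ccc(C)cc1)C1(C(=O)NCc2ccccc2)CCN(Cc2ccccc2)CC1`, is next to be measured in this assay. It differs from compound 3 in one place: 4-methylbenzyl in place of hydrogen on an amide-type nitrogen. Among the measured compounds shown here, no single-change step between measured compounds exists to guide this. The values of compound 1 and compound 2 sit slightly under that of compound 3, so compound 4 is expected to show a small downward step of a 1.5-fold lower number from compound 3 to compound 4 (0.19 log units; within the scatter), not beyond the scatter. Compound 4 is expected to give 65000 nM, within 30000 nM to 130000 nM.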

Compound 4, minimum cytotoxic concentration: > 100000 nM
Compound 4: no number, only a limit; the forecaster's own chance of this, stated with the estimate: 10%; at least 1.5-fold (0.18 log units) between middle value and limit.
By their numbers in this assay, from the lowest: compounds 1, 2 and 3 (each within the scatter of the next).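

In this assay, 4-methylbenzyl in place of hydrogen on the amide-type nitrogen gives a number no lower from compound 3 to compound 4 (the limit leaves the size open). Among the compounds shown here, this nitrogen therefore takes the added 4-methylbenzyl with no readable fall in the tolerated concentration, which the earlier compounds, joined by no single-change step, could not show. Compound 4 stands at a limit, not at a number: the limit of > 100000 nM in this assay, at which 1 of the 4 values shown sits.

On these data alone, how far compound 4 lies from compound 3 remains open. Also open, as far as these compounds go, is how this nitrogen tolerates other groups, such as a benzyl carrying a carboxylic acid or an amine.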